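Methyl on the carbinol carbon of an alkynyl oxindole

The compounds below may be only part of what the source reports. "The series", "measured", "known", "first", "only" and "open" are said of these compounds alone.

Compound 1 `COc1cc[nH]c1/C=C1\C(=O)Nc2ccc(F)c(I)c21` reaches only the limit of > 30000 nM in a functional assay on MDA-MB-435 cells (Homo sapiens) for inhibition; on this read-out lower numbers stand for stronger inhibition and higher numbers for weaker inhibition. Compound 2 `COc1cc[nH]c1/C=C1\C(=O)Nc2ccc(F)c(C#C[C@@H](C)O)c21` gives 110 nM in this assay. Compound 3 `CN[C@H](C#Cc1c(F)ccc2c1/C(=C/c1[nH]ccc1OC)C(=O)N2)CO` gives 349 nM in this assay.

Among the two actual numbers, compound 3 stands highest, and its nearest neighbour is compound 2 with a 3.2-fold higher number from compound 2 to compound 3 (0.50 log units; beyond the scatter). The replacement of the iodo group brings a large change either way, an at least 270-fold lower number from compound 1 to compound 2 (2.43 log units; beyond the scatter) and an at least 85-fold lower number from compound 1 to compound 3 (1.93 log units; beyond the scatter), although each of these rests on a limit, (the limit of > 30000 nM in this assay, at which 1 of the 3 values shown sits).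

Compound 4 `CN[C@H](C#Cc1c(F)ccc2c1/C(=C/c1[nH]ccc1OC)C(=O)N2)[C@@H](C)O` differs from compound 3 by methyl in place of hydrogen on a saturated chain carbon bound to an oxygen on a saturated carbon and a saturated chain carbon. For the measured compounds named here, the only measured step that touches this part of the molecule is the modest one from compound 2 to compound 3, which exchanges the terminal group on the triple-bonded carbon; compound 4 carries both the methylamino group of compound 3 and a methyl on the carbinol carbon as in compound 2. Going by the values given here, no step among the measured compounds isolates a single methyl at this position. A small change is therefore expected, a 1.4-fold lower number from compound 3 to compound 4 (0.14 log units; within the scatter), in the direction of compound 2. Compound 4 is expected to give 250 nM, with a range from 80 nM to 800 nM.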

Compound 4, half-maximal inhibitory concentration: 358 nM
Compound 4: the middle estimate sits 1.4-fold (0.16 log units) below what was measured, and the stated range covers the measured number.
By their numbers in this assay, from the lowest: compound 2; then compounds 3 and 4 (each within the scatter of the next). At a limit, above all of these: compound 1.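

For the compounds shown here, compound 4 gives the first reading of a single methyl at this position, and in this assay methyl in place of hydrogen on the saturated chain carbon bound to an oxygen leaves the result within the scatter: a 1.0-fold higher number from compound 3 to compound 4 (0.01 log units; within the scatter). The methyl does not close the gap to compound 2, which stays modest and beyond the scatter, with a 3.3-fold higher number from compound 2 to compound 4 (0.51 log units; beyond the scatter), so a 2-hydroxy-1-(methylamino)propyl group reads much as the 2-hydroxy-1-(methylamino)ethyl group of compound 3 does. Replacing iodo with the 4-hydroxy-3-(methylamino)pent-1-yn-1-yl group remains a large step, an at least 83-fold lower number from compound 1 to compound 4 (1.92 log units; beyond the scatter), but compound 1 stands at a limit, so the size of that step is bounded and not exact: the limit of > 30000 nM in this assay, at which 1 of the 4 values shown sits.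

The compounds shown leave open whether the methyl would also read as neutral without the methylamino group, as in a hydroxymethyl on the triple-bonded carbon compared directly with the 1-hydroxyethyl of compound 2. They also leave open how an ethyl or a longer chain at this position, the opposite configuration at this carbon, or a dimethylamino group in place of methylamino would read.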